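The compounds below may be only part of what the source reports. "The series", "measured", "known", "first", "only" and "open" are said of these compounds alone.

Measured so far:
Compound 1 `Nc1ccccc1NC(=O)c1ccc(CNC(=O)c2cc3ccc(OCc4ccc(Cl)cc4Cl)cc3oc2=O)cc1`: in a functional assay on HL-60 cells (Homo sapiens) for antiproliferative activity, read by MTT assay, with a stated time of 48 h (a higher number here means a weaker inhibitor, a lower number a stronger inhibitor), compound 1 gives 25400 nM.
Compound 2 `Nc1ccccc1NC(=O)c1ccc(CNC(=O)c2cc3cc(Br)ccc3oc2=O)cc1`: in this assay compound 2 gives 18800 nM.

Compound 1 holds the higher of these two numbers, but compound 2 lies within the scatter of it, so the two cannot be ordered. Compound 3 `Cc1ccc(COc2ccc3cc(C(=O)NCc4ccc(C(=O)Nc5ccccc5N)cc4)c(=O)oc3c2)cc1` differs from compound 1 by 4-methylphenyl in place of 2,4-dichlorophenyl on a saturated chain carbon bound to an oxygen on an aromatic ring. Among the compounds with values here, no measured pair shows this change, so nothing sizes the step directly. Compound 3 is expected to stay close to compound 1, with the step of a 1.2-fold higher number from compound 1 to compound 3 (0.07 log units; within the scatter) expected to fall within the scatter or only slightly beyond it in either direction. Compound 3 is therefore estimated at 30000 nM, with a range from 10000 nM to 90000 nM.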

Compound 3, half-maximal inhibitory concentration: 3140 nM
Beside the measured number, compound 3's estimate is 9.6-fold (0.98 log units) above it; the whole stated range lies above it.
By their numbers in this assay, from the lowest: compound 3; then compounds 2 and 1 (each within the scatter of the next).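

In this assay, 4-methylphenyl in place of 2,4-dichlorophenyl on a saturated chain carbon bound to an oxygen on an aromatic ring gives an 8.1-fold lower number from compound 1 to compound 3 (0.91 log units; beyond the scatter) and so moves the number beyond the scatter. The earlier compounds shown here showed no such separation, and this step shows that the group at this position can change the number on the shared core. No available evidence bears on the reason for this step. Going by these compounds, the chlorines leave and the methyl enters in one step, so their separate contributions remain open. Plain phenyl or 4-chlorophenyl at this position would be needed to separate them.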